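The source may hold more compounds than are shown below. What is called first, only, known or untested is meant among the compounds shown, and "the series" means these compounds.

Measured so far in an assay on MDA-MB-231 cells for binding affinity to C-X-C chemokine receptor type 4 (Homo sapiens), read by immunofluorescence and microscopy, with stated times of 10 min and 30 min; a lower number here means that less compound is needed, a higher number that more compound is needed for the effect:
- compound 1 `Cc1ccc(C(=O)NCc2ccc(CNS(=O)(=O)c3ccc(C)cc3)cc2)cc1`: 1000 nM
- compound 2 `O=C(NCc1ccc(CNS(=O)(=O)c2ccccc2)cc1)c1ccccc1Cl`: 10 nM
- compound 3 `O=C(NCc1ccc(CNS(=O)(=O)c2ccccc2)cc1)c1cccc(Cl)c1`: 1000 nM

Compound 1 stands level with compound 3 at the digits shown, the two together giving the highest numbers of the three; compound 2 lies far lower, which is the only large step seen: a 100-fold higher number from compound 2 to compound 3 (2.00 log units; beyond the scatter).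

Compound 4 `Cc1ccc(S(=O)(=O)NCc2ccc(CNC(=O)c3ccc(F)cc3)cc2)cc1` differs from compound 1 by fluoro in place of methyl on an aromatic carbon. Within the data shown here, no measured step exchanges groups at this position, so nothing here bears directly on the change; the one large step concerns the position of a chloro group, not a swap of groups at a fixed position. Without such a reference, the expectation for this assay is no step beyond the scatter, no change at the digits printed from compound 1 to compound 4 (within the scatter).

Compound 4 is therefore estimated at 1000 nM, with a range of 300 nM to 3000 nM.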

Compound 4, effective concentration (reported as EC, without a stated level of effect): 1 nM
Beside the measured number, compound 4's estimate is 1000-fold (3.00 log units) above it; the whole stated range lies above it.
By their numbers in this assay, from the lowest: compound 4; then compound 2; then compounds 1 and 3 (each within the scatter of the next).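

In this assay, 4-fluorophenyl in place of 4-methylphenyl on the carbonyl gives a 1000-fold lower number from compound 1 to compound 4 (3.00 log units; beyond the scatter), so the group para to a large group on this ring is highly sensitive to the exchange of one heavy atom. The earlier step showed sensitivity to where a chloro group sits; this one shows that the identity of the group at a fixed position also matters. No measurement shown accounts for the size of this step.

On these data alone, whether a methoxy or trifluoromethyl group at this position would track fluoro or methyl remains open. Also open, as far as these compounds go, is whether the same exchange would give a similar step in a compound with an unsubstituted phenyl on the sulfonyl.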